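Removing the para-fluorine from a stilbene-chalcone hybrid

The source may hold more compounds than are shown below. What is called first, only, known or untested is meant among the compounds shown, and "the series" means these compounds.

Two compounds have been measured so far:
- compound 1, `CCCCCCOc1ccc(C(=O)/C=C/c2c(/C=C/c3ccc(OC)cc3)cc(OC)cc2OC)cc1`: 10.4 ug/mL
- compound 2, `COc1ccc(/C=C/c2cc(OC)cc(OC)c2/C=C/C(=O)c2ccc(F)cc2)cc1`: 5.3 ug/mL

Both were tested in a functional assay on B16-F10 cells (Mus musculus) for antiproliferative activity, read by MTT assay, with a stated time of 48 h; a lower number here means a stronger inhibitor, a higher number a weaker inhibitor. Compound 2 gives the lowest of the two numbers, with compound 1 the nearest at a step that lies within the scatter, so the two cannot be ordered on these data. Going by the values given here, the one measured step, a 2.0-fold lower number from compound 1 to compound 2 (0.29 log units; within the scatter), concerns the same aromatic carbon of the benzoyl ring that changes next.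

Compound 3, `COc1ccc(/C=C/c2cc(OC)cc(OC)c2/C=C/C(=O)c2ccccc2)cc1`, has not yet been measured. It differs from compound 2 by hydrogen in place of fluoro on an aromatic carbon. The step from compound 1 to compound 2 is the only one that bears on this position, and it stayed within the scatter even though a hexyloxy group was exchanged for fluoro. On that basis a step of a 1.1-fold higher number from compound 2 to compound 3 (0.05 log units; within the scatter) is expected for compound 3, that is, nothing beyond the scatter in either direction. The value estimated for compound 3 in this assay is 6 ug/mL, within a range from 3 ug/mL to 12 ug/mL.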

Compound 3, half-maximal inhibitory concentration: 3.7 ug/mL
Estimate against measurement, compound 3: 1.6-fold (0.21 log units) above; low and high end bracket the measured number.
By their numbers in this assay, from the lowest: compounds 3, 2 and 1 (each within the scatter of the next, the first and the last beyond it).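

In this assay, the exchange of fluoro for hydrogen gives a 1.4-fold lower number from compound 2 to compound 3 (0.16 log units; within the scatter), so the fluorine on this aromatic carbon can be removed without a change that stands out from the scatter, and the 4-fluorophenyl and phenyl forms cannot be told apart here. Going by these compounds alone, the new compound also gives the first step at this position that exceeds the scatter, a 2.8-fold lower number from compound 1 to compound 3 (0.45 log units; beyond the scatter); the hexyloxy group and hydrogen can therefore be separated, though only modestly, while fluoro remains within the scatter of each. Nothing available accounts for either step.

The compounds shown leave open what an ethoxy group, an amine or a carboxylic acid would give on this carbon, and so whether the separation between hexyloxy and hydrogen follows the length of the chain or something else about the group. They also leave open whether the same small differences would hold on the other carbons of this ring, where any substituent, such as a chlorine, might behave differently from the fluorine studied here.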